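The source may hold more compounds than are shown below. What is called first, only, known or untested is meant among the compounds shown, and "the series" means these compounds.

Compound 2 `CC(C)=CCc1cc(C(=O)Nc2cc3ccc(OCCCN4CCCC4)c(C)c3oc2=O)ccc1O` is the starting point. In a functional assay on MCF7 cells (Homo sapiens) for antiproliferative activity (on this read-out lower numbers stand for stronger inhibition and higher numbers for weaker inhibition), compound 2 gives 990 nM, the lowest of the two numbers recorded here. Compound 3 `CC(C)=CCc1cc(C(=O)Nc2cc3ccc(OCCCN(C)C(C)(C)C)c(C)c3oc2=O)ccc1O` sits close by, giving 1140 nM in this assay. For compound 1 `CC(C)=CCc1cc(C(=O)Nc2cc3ccc(OCCCN4CCCCC4)c(C)c3oc2=O)ccc1O` the read-out is a limit rather than a number, > 50000 nM; this is the limit of > 50000 nM in this assay, at which 1 of the 3 values shown sits.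

Among the measured steps, an at least 50-fold lower number from compound 1 to compound 2 (1.70 log units; beyond the scatter) and an at least 43-fold lower number from compound 1 to compound 3 (1.64 log units; beyond the scatter) were both large, whereas a 1.2-fold higher number from compound 2 to compound 3 (0.06 log units; within the scatter). The group at this position therefore matters a great deal in some cases and hardly at all in others.

Compound 4 `CC(C)=CCc1cc(C(=O)Nc2cc3ccc(OCCCN(C)c4ccccc4)c(C)c3oc2=O)ccc1O` carries a change at the same position: methyl(phenyl)amino in place of pyrrolidin-1-yl on a saturated chain carbon, three bonds along the chain from an oxygen on an aromatic ring. Within the data shown here, the step from compound 2 to compound 3 is the nearest precedent, but methyl(phenyl)amino resembles neither of the groups tried so far, and the step from compound 1 to compound 2 shows how far the number can move. A moderately higher number is expected, with wide uncertainty. Compound 4 is thus estimated at 3000 nM, between 700 nM and 15000 nM. The expected step is a 3.0-fold higher number from compound 2 to compound 4 (0.48 log units; beyond the scatter).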

Compound 4, half-maximal inhibitory concentration: > 50000 nM
Compound 4: only a limit was reported (the forecaster's own chance of this, stated with the estimate: 15%); middle value at least 16-fold (1.22 log units) from the limit.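

Methyl(phenyl)amino in place of pyrrolidin-1-yl gives an at least 50-fold higher number from compound 2 to compound 4 (1.70 log units; beyond the scatter), so a loss of activity this large is no longer seen with piperidin-1-yl alone. Phenyl in place of tert-butyl on the amine nitrogen gives an at least 43-fold higher number from compound 3 to compound 4 (1.64 log units; beyond the scatter), which shows that open-chain amines at this place do not all behave alike and that this one change on the nitrogen is enough to separate them. The result for compound 4 is a limit, as is the result for compound 1, so the step between these two cannot be read: the limit of > 50000 nM in this assay, at which 2 of the 4 values shown sit.

The compounds shown leave open whether dimethylamino or morpholin-4-yl on the same chain would stay close to compound 2 or fall to the limit. They also leave open whether a longer chain would change the picture for pyrrolidin-1-yl.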